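Notes on the furfurylamine series: tert-butyl for methoxy

This account rests on a few compounds, and the source may have more. Where it says the series, first, only, none or still open, it means among the compounds named here.

Measured compounds:
compound 1 `c1ccc(-c2ccc3c(NCCCNCc4ccco4)ccnc3c2)cc1` — 9.47
compound 2 `Fc1ccc(Cc2ccc3c(NCCCNCc4ccco4)ccnc3c2)c(Cl)c1` — 9.47
compound 3 `COc1ccc(-c2ccc3c(NCCCNCc4ccco4)ccnc3c2)cc1` — 9.47

In a physicochemical assay for acid dissociation, compound 3 gives 9.47, level with compounds 1 and 2 at the digits shown. Its nearest neighbour on the numbers is compound 1 and its furthest is compound 2, and even that gap lies within the scatter. The steps recorded so far all bear on changes at the same aromatic carbon of the shared core: no change at the digits printed from compound 1 to compound 3 (within the scatter), no change at the digits printed from compound 1 to compound 2 (within the scatter) and no change at the digits printed from compound 2 to compound 3 (within the scatter). Three different groups at that position, from phenyl through 4-methoxyphenyl to 2-chloro-4-fluorobenzyl, leave this assay untouched.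

Compound 4 `CC(C)(C)c1ccc(-c2ccc3c(NCCCNCc4ccco4)ccnc3c2)cc1` continues the same line. The change is tert-butyl in place of methoxy on an aromatic carbon. Given that no step in this set has moved this assay, the step from compound 3 to compound 4 is expected to be no change at the digits printed from compound 3 to compound 4 (within the scatter), that is, nothing beyond the scatter. Compound 4 is therefore estimated at 9.47, with a range of 9.2 to 9.75.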

Compound 4, acid dissociation constant: 9.47
Estimate against measurement, compound 4: no gap at the digits printed, within the range that was stated.
By their numbers in this assay, from the lowest: compounds 1, 2, 3 and 4 (each within the scatter of the next).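

In this assay, tert-butyl in place of methoxy gives no change at the digits printed from compound 3 to compound 4 (within the scatter), so a group with no hydrogen-bond acceptor and an all-carbon count of 4 heavy atoms reads the same here as one with a hydrogen-bond acceptor and an oxygen. Among the compounds shown here, the other comparisons agree, with no change at the digits printed from compound 2 to compound 4 (within the scatter) and no change at the digits printed from compound 1 to compound 4 (within the scatter), and no compound among the four goes against this flat reading at the aromatic carbon. No supporting measurement accounts for this flat reading.

Still open, as far as these compounds go, is whether an amine or a carboxylic acid on the same six-membered aromatic ring of carbon only would leave this assay equally flat. Also open, from the compounds shown here alone, is whether a change in the furfurylamine part, such as a longer chain, would move it.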